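Benzyl to phenyl on sulfur and growth inhibition

The compounds below may be only part of what the source reports. "The series", "measured", "known", "first", "only" and "open" are said of these compounds alone.

Measured compounds:
Compound 1 `Cc1ccc(S/C(=C/c2sccc2C)C(=O)c2ccc(Cl)cc2)cc1` in a functional assay on DU-145 cells (Homo sapiens) for inhibition, read by trypan blue exclusion, with a stated time of 96 h (a higher number here means a weaker inhibitor of growth, a lower number a stronger inhibitor of growth), gives 50000 nM.
Compound 2 `CCOc1ccc(/C=C(/SCc2ccc(C)cc2)C(=O)c2ccc(Cl)cc2)cc1OC` in this assay gives 25000 nM.
Compound 3 `Cc1ccc(CS/C(=C/c2sccc2C)C(=O)c2ccc(Cl)cc2)cc1` in this assay gives 10000 nM.

Compounds 1 and 3 share one core and differ only in the group on the sulfur: 4-methylphenyl in place of 4-methylbenzyl on a sulfur. The step that this change made in this assay is a 5.0-fold higher number from compound 3 to compound 1 (0.70 log units; beyond the scatter), so the 4-methylphenyl compound came out as the weaker growth inhibitor of the pair.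

Compound 2 carries a different core; the difference between the cores of compound 2 and compound 3 is not broken down here. Among the three values compound 2 stands second highest, within the scatter of compound 1 and beyond the scatter of compound 3.

Compound 4 `CCOc1ccc(/C=C(/Sc2ccc(C)cc2)C(=O)c2ccc(Cl)cc2)cc1OC` has not yet been measured. It stands to compound 2 as compound 1 stands to compound 3: 4-methylphenyl in place of 4-methylbenzyl on a sulfur. The two place descriptions are the same word for word, so this is the same change on a different core. Going by the values given here, the expectation rests on the one precedent, the step of a 5.0-fold higher number from compound 3 to compound 1 (0.70 log units; beyond the scatter), and on compound 2 starting from 25000 nM. For compound 4 the expected step is a 4.0-fold higher number from compound 2 to compound 4 (0.60 log units; beyond the scatter). Compound 4 is accordingly estimated at 100000 nM, expected between 40000 nM and 300000 nM. Among the compounds with values here, the single precedent is on another core. Compound 1 already lies at 50000 nM. A still higher number for compound 4 may therefore fall outside what the assay can resolve.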

Compound 4, concentration for 50% growth inhibition: 25000 nM
The estimate for compound 4 lay 4.0-fold (0.60 log units) above the measured number, outside the stated range (below it).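

Replacing 4-methylbenzyl with 4-methylphenyl on the sulfur does not give the same result on both cores in this assay: the same change on two cores in this assay, a 5.0-fold higher number (0.70 log units; beyond the scatter) from compound 3 to compound 1 and no change at the digits printed (within the scatter) from compound 2 to compound 4, 5.0-fold (0.70 log units) apart, beyond the scatter of two such steps

The newer pair shows no change at the digits printed from compound 2 to compound 4 (within the scatter), so the weaker growth inhibition seen with 4-methylphenyl on the other core cannot be treated as a fixed increment to carry across this series. Going by these compounds alone, with only two matched pairs, the data show that the outcome of this change depends on the core, but not which part of the core is responsible, nor how the change would behave on a third core.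

The compounds shown leave open whether any group on the sulfur gives stronger growth inhibition on either core, since only 4-methylbenzyl and 4-methylphenyl appear there, and a longer chain such as 2-phenylethyl would test the link between the sulfur and the aromatic ring. They also leave open whether an amine or a carboxylic acid on that aromatic ring would separate the two cores further or bring their responses to this change together.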